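Para-selenocyanato aryl carbamates: cytotoxicity on airway cells

This account rests on a few compounds, and the source may have more. Where it says the series, first, only, none or still open, it means among the compounds named here.

Three carbamates of the same selenocyanate-bearing aniline have been measured in an ADME assay on BEAS-2B cells (Homo sapiens) for cytotoxicity, read by MTT assay, with a stated time of 72 h; a higher number here means a weaker inhibitor of growth, a lower number a stronger inhibitor of growth. Compound 1 `COc1ccc(OC(=O)Nc2ccc([Se]C#N)cc2)cc1` gives 48400 nM. Compound 2 `C=CCOC(=O)Nc1ccc([Se]C#N)cc1` gives 47400 nM. Compound 3 `Cc1ccc(OC(=O)Nc2ccc([Se]C#N)cc2)cc1` gives 15300 nM and thus stands lowest of the three, with compound 2 and compound 1 both above it by steps beyond the scatter. For the measured compounds named here, the only single-point step among them is a 3.2-fold lower number from compound 1 to compound 3 (0.50 log units; beyond the scatter), which concerns the group on the aromatic carbon of the phenyl carbamate.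

Compound 4 `N#C[Se]c1ccc(NC(=O)Oc2ccccc2)cc1` follows from compound 3 by hydrogen in place of methyl on an aromatic carbon. Going by the values given here, no measured pair reports the exchange of a methyl for a hydrogen at this place; the step from compound 1 to compound 3 shows only that swapping the group on that carbon shifts the number modestly. Taking that step as the scale of what a change at this position can do, and without a measured direction for removal of the methyl, the estimate for compound 4 is a 1.6-fold higher number from compound 3 to compound 4 (0.21 log units; within the scatter), with the number expected to lie between those of compound 3 and compound 1 rather than outside them. Compound 4 is therefore expected to give about 25000 nM in this assay, within 10000 nM to 60000 nM.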

Compound 4, concentration for total growth inhibition: 38200 nM
For compound 4 the middle estimate is 1.5-fold (0.18 log units) below the measured one, and the stated range covers the measured number.
By their numbers in this assay, from the lowest: compound 3; then compounds 4, 2 and 1 (each within the scatter of the next).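

Working notes on the phenyl carbamate position: in this assay the removal of the methyl now has a measured direction, a 2.5-fold higher number from compound 3 to compound 4 (0.40 log units; beyond the scatter), which sets the methyl on this aromatic carbon, para to a large group, apart from hydrogen. Hydrogen in place of methoxy at the same carbon gives a 1.3-fold lower number from compound 1 to compound 4 (0.10 log units; within the scatter) and stays within the scatter, so of the three groups seen here only the methyl separates from the others. On the oxygen next to the carbonyl group, phenyl in place of allyl gives a 1.2-fold lower number from compound 2 to compound 4 (0.09 log units; within the scatter) and also stays within the scatter, so the unsubstituted phenyl and the allyl carbamates cannot be told apart in this read-out.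

Still open, as far as these compounds go, is whether the shift belongs to the methyl alone or extends to other groups at this carbon, such as an ethyl, a chlorine or an amine, and whether a longer chain on the carbamate oxygen would move the number. Nothing available explains the shift seen with the methyl.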